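This account rests on a few compounds, and the source may have more. Where it says the series, first, only, none or still open, it means among the compounds named here.

Measured compounds:
Compound 1, `COc1ccc(-c2nnc(NC(=O)/C=C/c3ccccc3)s2)cc1`, gives 0.68 ug/mL in a functional assay on A549 cells (Homo sapiens) for antiproliferative activity, read by MTT assay, with a stated time of 48 h; a lower number here means a stronger inhibitor, a higher number a weaker inhibitor.
Compound 2, `O=C(/C=C/c1ccccc1)Nc1nnc(-c2ccc(Br)cc2)s1`, gives 2.18 ug/mL in this assay.
Compound 3, `COc1ccc(/C=C/C(=O)Nc2nnc(-c3ccc(OC)cc3)s2)cc1`, gives 0.52 ug/mL in this assay.

Compounds 1 and 3 share a core and differ only in one place: methoxy in place of hydrogen on an aromatic carbon. The two numbers sit close together, and the step of a 1.3-fold lower number from compound 1 to compound 3 (0.12 log units; within the scatter) says nothing firm about a difference between them. Among the measured compounds shown here, compound 2 stands apart from both of them in this assay, and the one change that separates it from compound 1 is bromo in place of methoxy on an aromatic carbon, which gave the step of a 3.2-fold higher number from compound 1 to compound 2 (0.51 log units; beyond the scatter).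

Compound 4, `COc1ccc(/C=C/C(=O)Nc2nnc(-c3ccc(Br)cc3)s2)cc1`, is not yet measured. It differs from compound 3 by bromo in place of methoxy on an aromatic carbon, at a place described in the same words as the change from compound 1 to compound 2, so it is the same change, seen here in two occurrences among these compounds. For the measured compounds named here, no other measured pair shows it, so the single step of a 3.2-fold higher number from compound 1 to compound 2 (0.51 log units; beyond the scatter) is all there is to go on, together with the starting value of compound 3, 0.52 ug/mL.

Going by the values given here, on that basis compound 4 is expected to come out weaker than compound 3, with a step of about a 3.3-fold higher number from compound 3 to compound 4 (0.51 log units; beyond the scatter), because the step of a 3.2-fold higher number from compound 1 to compound 2 (0.51 log units; beyond the scatter) is the only guide. The estimated value for compound 4 in this assay is 1.7 ug/mL, expected to fall between 0.8 ug/mL and 3.6 ug/mL.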

Compound 4, half-maximal inhibitory concentration: 1.04 ug/mL
Estimate against measurement, compound 4: 1.6-fold (0.21 log units) above; measured number inside the range.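

Across the four compounds in this assay, bromo in place of methoxy gives a 2.0-fold higher number from compound 3 to compound 4 (0.30 log units; within the scatter), a step that on its own cannot be told from scatter but that does not differ from the one seen on the other core: the same change on two cores in this assay, a 3.2-fold higher number (0.51 log units; beyond the scatter) from compound 1 to compound 2 and a 2.0-fold higher number (0.30 log units; within the scatter) from compound 3 to compound 4, 1.6-fold (0.20 log units) apart, within the scatter of two such steps. Methoxy in place of hydrogen gives a 2.1-fold lower number from compound 2 to compound 4 (0.32 log units; beyond the scatter), a modest step on this core, and it too does not differ from its counterpart on the other core, even though that counterpart lies within the scatter: the same change on two cores in this assay, a 1.3-fold lower number (0.12 log units; within the scatter) from compound 1 to compound 3 and a 2.1-fold lower number (0.32 log units; beyond the scatter) from compound 2 to compound 4, 1.6-fold (0.20 log units) apart, within the scatter of two such steps. So each change can be carried from one core to the other with no detectable difference in size, but this rests on only two pairs per change, and neither change is shown beyond the scatter on both cores, so the data neither fix a firm size for either step nor show that the two changes add up in general.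

The compounds shown leave open how the steps would run with an amine, a carboxylic acid or a longer alkoxy chain on these aromatic carbons. They also leave open whether the agreement would hold on a third core, or with the amide or the alkene altered.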